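A few compounds are considered here, and "the series" means these few. Any claim that something is new, unique, unknown or untested is made for them only; others in the source may bear on it.

Compound 1 `CC(=O)OCc1cc(=O)n(-c2ccccc2)s1`: 162000 nM
Compound 2 `Cc1cc(=O)n(-c2ccccc2)s1`: > 200000 nM
Compound 3 `Cc1csn(-c2ccccc2)c1=O`: 32000 nM

All three were tested in an assay for inhibition of histone acetyltransferase KAT2B (Homo sapiens); a higher number here means a weaker inhibitor, a lower number a stronger inhibitor. Compound 1 gives 162000 nM in this assay. For compound 2 the value > 200000 nM is a limit of the assay, not a number. Compound 3 gives 32000 nM, the lower of the two numbers measured, and its gap to compound 1 lies beyond the usual scatter.

Compound 4 `[N-]=[N+]=NCc1csn(-c2ccccc2)c1=O` differs from compound 3 by azido in place of hydrogen on a saturated chain carbon bound to an aromatic carbon. Among the measured compounds shown here, the only measured step at this kind of position is an at least 1.2-fold higher number from compound 1 to compound 2 (0.09 log units; that floor lies within the scatter), where removing the acetoxy group left the number higher, though how much higher is unknown because compound 2 sits at the limit of > 200000 nM in this assay, at which 1 of the 3 values shown sits. That step involves a different group and is known only as a floor, so it carries over weakly. Adding a small group at this position is therefore expected to move the number little, if at all, with at most a slight drop, giving an expected step of a 1.5-fold lower number from compound 3 to compound 4 (0.16 log units; within the scatter). Compound 4 is estimated at 22000 nM, with a likely range from 8000 nM to 70000 nM.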

Compound 4, half-maximal inhibitory concentration: 42700 nM
The estimate for compound 4 lay 1.9-fold (0.29 log units) below the measured number; low and high end bracket the measured number.
By their numbers in this assay, from the lowest: compounds 3 and 4 (each within the scatter of the next); then compound 1. At a limit, above all of these: compound 2.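

In this assay the new pair gives a 1.3-fold higher number from compound 3 to compound 4 (0.13 log units; within the scatter). On the core of compound 3, then, this saturated chain carbon takes an azido group, 3 heavy atoms in place of a hydrogen, with no difference that can be told apart from the scatter of repeated measurements. This is the first step at this kind of position with a real number at both ends, and the only earlier step could give no size because compound 2 stands at a limit: the limit of > 200000 nM in this assay, at which 1 of the 4 values shown sits.

A single azido group on a single core says little about the position in general, and nothing about how an amine, a carboxylic acid or a longer chain on this carbon would fare. Also open, from the compounds shown here alone, is whether the same change from methyl to azidomethyl would behave alike on the core of compound 2.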